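This account rests on a few compounds, and the source may have more. Where it says the series, first, only, none or still open, it means among the compounds named here.

Within the data shown here, in an ADME assay on 184B5 cells (Homo sapiens) for antiproliferative activity, read by sulforhodamine B assay, with a stated time of 72 h (on this read-out higher numbers stand for weaker inhibition and lower numbers for stronger inhibition), compound 2 `COc1ccc2nc(Cl)c(/C=C\c3ccc(C(F)(F)F)cc3)cc2c1` gives 40000 nM, the higher of the two numbers measured so far and therefore the weaker inhibition. Among the measured compounds shown here, the only other measured compound, compound 1 `FC(F)(F)c1ccc(/C=C\c2cc3ccccc3nc2Cl)cc1`, gives 7940 nM. For the measured compounds named here, the one measured step, a 5.0-fold higher number from compound 1 to compound 2 (0.70 log units; beyond the scatter), comes with methoxy in place of hydrogen on an aromatic carbon. Compound 3 `COc1ccc2nc(Cl)c(/C=C/c3ccc(C(F)(F)F)cc3)cc2c1` brings a change of a different kind: the two compounds have the same atoms and bonds and differ only in configuration as drawn: 1 of 1 stereo elements differ; a double bond is drawn Z in compound 2 and E in compound 3. A double bond is drawn Z in compound 2 and E in compound 3. Going by the values given here, no measured pair tests such a switch, so the methoxy step shows only how far one change has moved the number here and gives no direction for this one. The expected change is small, a 1.4-fold lower number from compound 2 to compound 3 (0.15 log units; within the scatter), and it is not expected to go beyond the scatter. Compound 3 is estimated at 28000 nM, with an expected range of 9000 nM to 60000 nM.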

Compound 3, half-maximal inhibitory concentration: 33500 nM
The estimate for compound 3 lay 1.2-fold (0.08 log units) below the measured number; the range from low to high includes it.
By their numbers in this assay, from the lowest: compound 1; then compounds 3 and 2 (each within the scatter of the next).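

In this assay, the switch of the double bond from Z to E comes with a 1.2-fold lower number from compound 2 to compound 3 (0.08 log units; within the scatter), so with the methoxy group in place, the drawn geometry of this bond makes no difference that can be told apart from ordinary repeat variation. Among these compounds, the earlier step tested a change of substituent, whereas this pair is the first to test configuration, and the comparison is a clean one because nothing else separates the two compounds: the fact that compounds 2 and 3 differ only in the configuration as drawn.

Whether the double bond's geometry matters as little without the methoxy group remains open, as compound 1 has no E partner among the compounds shown. These compounds also leave open how the number would respond if an amine or a carboxylic acid stood in place of the methoxy group.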